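The source may hold more compounds than are shown below. What is called first, only, known or untested is meant among the compounds shown, and "the series" means these compounds.

Measured compounds in a functional assay on HCC827 cells (Homo sapiens) for inhibition, read by fluorescence, with a stated time of 72 h; on this read-out lower numbers stand for stronger inhibition of growth and higher numbers for weaker inhibition of growth:
compound 1 `CCCCCCn1cnc2c(Nc3ccc(O)cc3)nc(N[C@H]3CC[C@H](N)CC3)nc21` gives 24700 nM
compound 2 `CC(C)CCn1cnc2c(NCc3cccc(Cl)c3)nc(N[C@H]3CC[C@H](N)CC3)nc21` gives 16700 nM
compound 3 `CC(C)CCn1cnc2c(Nc3ccc(Cl)cc3)nc(N[C@H]3CC[C@H](N)CC3)nc21` gives 10200 nM

Compound 2 stands second highest of the three numbers, and both neighbours lie within the scatter of it. Compound 4 `CC(C)CCn1cnc2c(Nc3cccc(O)c3)nc(N[C@H]3CC[C@H](N)CC3)nc21` carries 3-hydroxyphenyl in place of 3-chlorobenzyl on a nitrogen on an aromatic ring. Among the compounds with values here, the one measured step that bears on this is a 1.6-fold lower number from compound 2 to compound 3 (0.21 log units; within the scatter), where the 3-chlorobenzyl group also leaves; it was within the scatter. Compound 1, with a 4-hydroxyphenyl group on the same nitrogen, gives 24700 nM, again within the scatter of compound 2. Within the data shown here, nothing among the measured compounds points to a step beyond the scatter, so a number close to compound 2 is expected, a 1.0-fold lower number from compound 2 to compound 4 (0.02 log units; within the scatter). Compound 4 is therefore estimated at 16000 nM, with a range from 6000 nM to 40000 nM.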

Compound 4, concentration for 50% growth inhibition: 21300 nM
The estimate for compound 4 lay 1.3-fold (0.12 log units) below the measured number, and the stated range covers the measured number.
By their numbers in this assay, from the lowest: compounds 3, 2, 4 and 1 (each within the scatter of the next, the first and the last beyond it).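

In this assay, within the data shown here, the change to 3-hydroxyphenyl gives the first step at this nitrogen that lies beyond the scatter, though a modest one: a 2.1-fold higher number from compound 3 to compound 4 (0.32 log units; beyond the scatter). Against the benzyl group the same change stays within the scatter, a 1.3-fold higher number from compound 2 to compound 4 (0.11 log units; within the scatter), so 3-hydroxyphenyl and 3-chlorobenzyl are not separated on this read-out. No measured information accounts for either step. Still open, as far as these compounds go, is how an amine or a carboxylic acid in place of the hydroxyl would read. From the compounds shown here alone, it is also open whether the step from compound 3 follows from losing the chlorine or from the different ring placement.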